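Replacing the Aryl Amide of Compound 1 with Isopropyl

The source may hold more compounds than are shown below. What is called first, only, known or untested is meant among the compounds shown, and "the series" means these compounds.

Compound 1 `CC(C)c1ccc(NC(=O)[C@H]2CN(C)C[C@@H]2c2ccc(/C=C/C(=O)Nc3ccccc3N)cc2)cc1` was run in an in vitro ADME assay on microsomes from liver (Homo sapiens) for pharmacokinetics, read by LC-MS, with a stated time of 10 min, tested at 1 uM (on this read-out higher numbers stand for fast clearance and lower numbers for slow clearance), and gave 10 mL/min/kg, the second highest of the three numbers, with every neighbour within the scatter. Compound 2 `Cc1ccc(NC(=O)[C@H]2CN(C)C[C@@H]2c2ccc(/C=C/C(=O)Nc3ccccc3N)cc2)cn1` gave 8 mL/min/kg in this assay, and the step of a 1.3-fold lower number from compound 1 to compound 2 (0.10 log units; within the scatter). Compound 3 `CN1C[C@H](C(=O)Nc2ccc(Cl)cn2)[C@@H](c2ccc(/C=C/C(=O)Nc3ccccc3N)cc2)C1` gave 13 mL/min/kg, and the step of a 1.3-fold higher number from compound 1 to compound 3 (0.11 log units; within the scatter); between the two pyridyl amides the step of a 1.6-fold higher number from compound 2 to compound 3 (0.21 log units; within the scatter). Compound 4 `CC(C)NC(=O)[C@H]1CN(C)C[C@@H]1c1ccc(/C=C/C(=O)Nc2ccccc2N)cc1` differs from compound 1 as follows: isopropyl in place of 4-isopropylphenyl on an amide-type nitrogen. The three measured steps each exchange one six-membered aromatic ring on the amide-type nitrogen for another, and none of them removes the ring altogether, so they bear on this change only loosely; what they do show is that three different amide substituents all land close together in this assay. With no step beyond the scatter among them, compound 4 is expected to stay near compound 1, and the step of a 1.1-fold lower number from compound 1 to compound 4 (0.05 log units; within the scatter) is the estimate. For compound 4 the expected value in this assay is 9 mL/min/kg, with a range of 4 mL/min/kg to 20 mL/min/kg.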

Compound 4, clearance: 8 mL/min/kg
For compound 4 the middle estimate is 1.1-fold (0.05 log units) above the measured one; the measured number falls inside the stated range.
By their numbers in this assay, from the lowest: compounds 2, 4, 1 and 3 (each within the scatter of the next).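

Taking the aromatic ring off this amide-type nitrogen altogether, a change none of the earlier steps made, still leaves the read-out in this assay within the scatter, with a 1.3-fold lower number from compound 1 to compound 4 (0.10 log units; within the scatter) for the exchange of 4-isopropylphenyl for isopropyl. The comparison with the two pyridyl amides reads the same way, with a 1.6-fold lower number from compound 3 to compound 4 (0.21 log units; within the scatter) for the 5-chloropyridin-2-yl amide and no change at the digits printed from compound 2 to compound 4 (within the scatter) for the 6-methylpyridin-3-yl amide. Among these four compounds, then, clearance at this position does not depend on a ring being present on the nitrogen, and none of them goes against this. Still open, from the compounds shown here alone, is whether an amine, a carboxylic acid or a longer chain on this nitrogen would stay within the same narrow band. Nothing shown here gives a reason for this flat result.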